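Series notes: a substituent change at the shared core

The source may hold more compounds than are shown below. What is called first, only, known or untested is meant among the compounds shown, and "the series" means these compounds.

Measured so far in a functional assay on SK-OV-3 cells (Homo sapiens) for cytotoxicity, read by sulforhodamine B assay, with a stated time of 48 h; on this read-out lower numbers stand for stronger inhibition of growth and higher numbers for weaker inhibition of growth:
Compound 1 `ClCc1ccccc1Cn1cnc2c(Cl)nc(Cl)nc21` gives 1820 nM.
Compound 2 `ClCc1ccccc1Cn1cnc2c(Cl)ncnc21` gives 4170 nM.
Compound 3 `ClCc1cccc(Cn2cnc3c(Cl)ncnc32)c1` gives 3310 nM.

Compound 2 stands at the highest of the three numbers. Compound 3 is within the scatter of compound 2, so no order between them is claimed; compound 1 sits lower, beyond the scatter. Going by the values given here, the single step between compounds that differ in one place is a 2.3-fold higher number from compound 1 to compound 2 (0.36 log units; beyond the scatter), a modest loss when the chloro is removed from the aromatic carbon that sits between two ring nitrogen atoms.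

Compound 4 `Nc1nc(Cl)c2ncn(Cc3ccccc3CCl)c2n1` differs from compound 2 by amino in place of hydrogen on an aromatic carbon. Among the compounds with values here, the same position is touched as in the step from compound 1 to compound 2, but no measured step involves an amino group, so direction cannot be read from the data. That one step shows the position is responsive, which argues for a step of modest size rather than none. For compound 4 the expected outcome is a 1.4-fold lower number from compound 2 to compound 4 (0.14 log units; within the scatter), with an estimate of 3000 nM and a range from 1000 nM to 9000 nM.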

Compound 4, concentration for 50% growth inhibition: 15500 nM
Compound 4: the middle estimate sits 5.2-fold (0.71 log units) below what was measured, outside the stated range (above it).
By their numbers in this assay, from the lowest: compounds 1, 3 and 2 (each within the scatter of the next, the first and the last beyond it); then compound 4.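

In this assay, amino in place of hydrogen on the aromatic carbon between two ring nitrogen atoms gives a 3.7-fold higher number from compound 2 to compound 4 (0.57 log units; beyond the scatter) and so runs opposite to chloro, which gives the lower number of compound 1 against hydrogen in compound 2. The position therefore does more than respond: the direction of the step depends on the group placed there, and going from chloro to amino gives an 8.5-fold higher number from compound 1 to compound 4 (0.93 log units; beyond the scatter) across the same carbon. No measured information on the compounds explains this difference between the groups.

Open, on these data alone, is whether methoxy, methylamino or dimethylamino at this carbon would follow amino or chloro. Also open, as far as these compounds go, is whether the amino step would carry over to the other chloromethyl placement seen in compound 3.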